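The compounds below may be only part of what the source reports. "The series", "measured", "known", "first", "only" and "open" are said of these compounds alone.

Among the compounds with values here, compound 3 `Clc1ccc2c(-n3cc(-c4ccccc4)nn3)ccnc2c1` is the one compound among the three whose result in an ADME assay on HepG2 cells (Homo sapiens) for cytotoxicity, read by MTT assay, with a stated time of 24 h (on this read-out lower numbers stand for higher toxicity in this test and higher numbers for lower toxicity in this test), is a number: in this assay compound 3 gives 574000 nM. Compound 1 `CN(C)c1ccc(-c2cn(-c3ccnc4cc(Cl)ccc34)nn2)cc1` reaches only a limit of the assay, namely > 2860000 nM. Compound 2 `Fc1ccc(-c2cn(-c3ccnc4cc(Cl)ccc34)nn2)cc1` likewise stops at a limit, namely > 3080000 nM. Read against those limits, the steps down to compound 3 are an at least 4.9-fold lower number from compound 1 to compound 3 (0.69 log units; beyond the scatter) and an at least 5.3-fold lower number from compound 2 to compound 3 (0.72 log units; beyond the scatter), while a step that the two limits leave unreadable from compound 1 to compound 2.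

Compound 4 `CC(C)(O)c1cn(-c2ccnc3cc(Cl)ccc23)nn1` differs from compound 3 by 1-hydroxy-1-methylethyl in place of phenyl on an aromatic carbon. Within the data shown here, every measured step changes a substituent carried on the phenyl, whereas this change removes the phenyl itself, so no measured step bears directly on it. All that the three measured compounds show is that the two with a substituted phenyl sit at limits (the limit of > 2860000 nM in this assay, at which 1 of the 3 values shown sits, (the limit of > 3080000 nM in this assay, at which 1 of the 3 values shown sits)) and the one with a bare phenyl gives a number; whether replacing the phenyl by 1-hydroxy-1-methylethyl moves the number up or down cannot be read from them. Compound 4 is therefore expected to fall roughly in the span between compound 3 and the two limits, with a step of a 2.6-fold higher number from compound 3 to compound 4 (0.42 log units; beyond the scatter) estimated, and a value of 1500000 nM expected, within a range from 400000 nM to 5000000 nM.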

Compound 4, half-maximal cytotoxic concentration: 442000 nM
Estimate against measurement, compound 4: 3.4-fold (0.53 log units) above, within the range that was stated.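

In this assay, 1-hydroxy-1-methylethyl, a group with no ring that carries a hydrogen-bond donor, takes the place of the phenyl on the aromatic carbon of the five-membered ring, and the outcome is a 1.3-fold lower number from compound 3 to compound 4 (0.11 log units; within the scatter). The earlier steps all changed a substituent on the phenyl, so only this result shows that, among the compounds shown, the phenyl can be removed altogether from this position with no difference beyond the scatter between compound 3 and compound 4. Measured against the 4-fluorophenyl group instead, the same position gives an at least 6.9-fold lower number from compound 2 to compound 4 (0.84 log units; beyond the scatter), a step that starts from a limit and not from a number: the limit of > 3080000 nM in this assay, at which 1 of the 4 values shown sits.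

As far as these compounds go, it remains open whether the oxygen of 1-hydroxy-1-methylethyl plays any part in this result, which a tert-butyl group at the same place would help to settle. Also open, from the compounds shown here alone, is whether the flat result extends to groups of another kind at this position, such as an amine, a carboxylic acid or a longer chain.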